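The compounds below may be only part of what the source reports. "The series", "measured", "known", "first", "only" and "open" are said of these compounds alone.

Of the compounds shown here, three have been read in a functional assay on K562 cells (Homo sapiens), read by MTT assay, with a stated time of 72 h; a higher number here means a weaker inhibitor, a lower number a stronger inhibitor. Going by the values given here, compound 1 (`COc1ncnc2c1c(-c1cc3ccccc3o1)cn2[C@@H]1O[C@H](CO)[C@@H](O)[C@H]1O`) gives 13100 nM, the only full number so far. Compound 2 (`Nc1nc(N)c2c(-c3cc4ccccc4o3)cn([C@@H]3O[C@H](CO)[C@@H](O)[C@H]3O)c2n1`) gives > 20000 nM, which is a limit of the assay. Compound 3 (`COc1nc(N)nc2c1c(-c1ccccc1)cn2[C@@H]1O[C@H](CO)[C@@H](O)[C@H]1O`) gives > 20000 nM, also only a limit, so its true position is not known. Among the compounds with values here, the series so far rests largely on (the limit of > 20000 nM in this assay, at which 2 of the 3 values shown sit).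

Compound 4 (`COc1nc(N)nc2c1c(-c1cc3ccccc3o1)cn2[C@@H]1O[C@H](CO)[C@@H](O)[C@H]1O`) has 1-benzofuran-2-yl in place of phenyl on an aromatic carbon. The 1-benzofuran-2-yl group is carried by compound 1, at 13100 nM. Compound 2 carries it too and stays at its limit of > 20000 nM, so the group does not guarantee a measurable reading.

In this assay, only a small step toward lower numbers is expected, and a report at the limit remains quite likely. The expected change is an at least 1.2-fold lower number from compound 3 to compound 4 (0.09 log units; that floor lies within the scatter). The estimate for compound 4 is 16000 nM, with an expected range of 7000 nM to 35000 nM.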

Compound 4, half-maximal inhibitory concentration: 15500 nM
Compound 4: the middle estimate sits 1.0-fold (0.01 log units) above what was measured; low and high end bracket the measured number.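

In this assay, 1-benzofuran-2-yl in place of phenyl on this aromatic carbon gives a full reading where compound 3 had only a limit, with an at least 1.2-fold lower number from compound 3 to compound 4 (0.11 log units; that floor lies within the scatter), so only a floor on the step is known. With 1-benzofuran-2-yl held constant, methoxy in place of amino on an aromatic carbon also separates a full reading from a limit, with an at least 1.2-fold lower number from compound 2 to compound 4 (0.11 log units; that floor lies within the scatter). Amino in place of hydrogen on an aromatic carbon gives a 1.2-fold higher number from compound 1 to compound 4 (0.07 log units; within the scatter), so adding this amino makes no readable difference to the methoxy compounds.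

From the compounds shown here alone, the true size of the first two steps stays unknown because compounds 2 and 3 give only limits: the limit of > 20000 nM in this assay, at which 2 of the 4 values shown sit. Also open is how a carboxylic acid or an aliphatic amine on the 1-benzofuran-2-yl group would read in this assay.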